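The source may hold more compounds than are shown below. What is called first, only, known or untested is meant among the compounds shown, and "the series" means these compounds.

Compound 1 `COc1ccc(Cn2nncc2-c2cc(OC)c(OC)c(OC)c2)cc1Br` is reported in the cytotoxicity assay only as a limit, > 10000 nM. Compound 2 `COc1ccc(Cn2nncc2-c2cc(OC)c(OC)c(OC)c2)cc1O` gives 1830 nM. Compound 3 `COc1ccc(-c2cn(Cc3cc(OC)c(OC)c(OC)c3)nn2)cc1Br` is likewise reported only as a limit, > 10000 nM.

The read-out is a functional assay on K562 cells (Homo sapiens) for cytotoxicity, read by MTT assay, with a stated time of 5 days; a higher number here means a weaker inhibitor, a lower number a stronger inhibitor. In this assay compound 1 stands at the limit given above, so that the step of an at least 5.4-fold lower number from compound 1 to compound 2 (0.73 log units; beyond the scatter) is known only as a minimum; its true size cannot be fixed, because the limit of > 10000 nM in this assay, at which 2 of the 3 values shown sit, marks the point at which the value of compound 1 sits. The change behind that step is hydroxy in place of bromo on an aromatic carbon.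

Compound 4 `COc1ccc(-c2cn(Cc3cc(OC)c(OC)c(OC)c3)nn2)cc1O` carries the same change relative to compound 3: hydroxy in place of bromo on an aromatic carbon. The place described for the change is the same in both pairs, word for word. Compound 3 and compound 1 are built from the same atoms joined differently; the difference between the two cores is not broken down here.

Compound 3 sits at the limit of this assay, as compound 1 does, so the starting point for compound 4 is no better defined than it was for compound 2. The step expected from compound 3 to compound 4 in this assay, an at least 2.8-fold lower number from compound 3 to compound 4 (0.45 log units; beyond the scatter), is set beside an at least 5.4-fold lower number from compound 1 to compound 2 (0.73 log units; beyond the scatter) and rests on that single measured instance of the change; with the core change left unaccounted for, the expectation is held loosely. For compound 4 in this assay the estimate is 3500 nM, expected to fall between 1200 nM and 12000 nM.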

Compound 4, half-maximal inhibitory concentration: > 10000 nM
Compound 4 gave a limit, no number; the forecaster's own chance of this, stated with the estimate: 35%; middle value at least 2.8-fold (0.45 log units) away from the limit.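

In this assay compound 4 is reported only as a limit, > 10000 nM, as compound 3 also is, so no step can be read from compound 3 to compound 4: the limit of > 10000 nM in this assay, at which 3 of the 4 values shown sit.

The compounds shown leave open whether hydroxy in place of bromo on an aromatic carbon lowers the number at all on the core of compound 3, as it does on the core of compound 1.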